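The compounds below may be only part of what the source reports. "The series", "measured", "known", "first", "only" and "open" are said of these compounds alone.

Measured in an ADME assay on BJ cells (Homo sapiens) for cytotoxicity, read by luminescence, with a stated time of 72 h (on this read-out higher numbers stand for an effect only at larger amounts of compound and lower numbers for an effect already at smaller amounts), so far:
- compound 1 `CCOC(=O)c1c(-c2cccc(Oc3ccccc3)c2)[nH]c2cc(OC)c(OC)cc2c1=O` gives > 21500 nM as a limit
- compound 2 `CCOC(=O)c1c(-c2cccc(-c3ccccc3)c2)[nH]c2cc(Cl)c(OC)cc2c1=O` gives > 21500 nM as a limit
- compound 3 `CCOC(=O)c1c(-c2cccc(OC)c2)[nH]c2cc(Cl)c(OC)cc2c1=O` gives > 21500 nM as a limit

Within the data shown here, compound 3 therefore stands only at a limit and not at a number, and the limit of > 21500 nM in this assay, at which 3 of the 3 values shown sit, holds for all the compounds measured so far. The change to compound 4 `CCOC(=O)c1c(-c2cccc(Oc3ccccc3)c2)[nH]c2cc(Cl)c(OC)cc2c1=O` is phenyl in place of methyl on an oxygen on an aromatic ring, counted in full as phenyl in place of methyl on an oxygen on an aromatic ring for this pair. Among the measured compounds shown here, the only measured step is a step that the two limits leave unreadable from compound 2 to compound 3 and it gives no size to carry over. No step beyond the scatter is therefore expected in this assay and another limit is the likeliest report. The estimated change is a number no higher from compound 3 to compound 4 (the limit leaves the size open) in all. For compound 4 the estimate is 21500 nM within an expected range of 12000 nM to 30000 nM as the likely outcome.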

Compound 4, half-maximal effective concentration: > 21500 nM
Compound 4 gave a limit, no number; the forecaster's own chance of this, stated with the estimate: 90%; the middle value sits exactly at the limit.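

Among these compounds, compound 4 gives only a limit, as do compound 1, compound 2 and compound 3, so no step among them can be read: the limit of > 21500 nM in this assay, at which 4 of the 4 values shown sit. The compounds shown leave open which change, if any, would give a number instead of a limit.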